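The source may hold more compounds than are shown below. What is called first, only, known or untested is meant among the compounds shown, and "the series" means these compounds.

Compound 1 `CC(C)c1ncn2c(S)nncc12` and compound 2 `CSc1nncc2c(C(C)C)ncn12` share one core; compound 3 `Cc1nnc(S)n2c(C)nc(C)c12` and compound 4 `CSc1nnc(C)c2c(C)nc(C)n12` share another, and the difference between the two cores is not broken down here. In a functional assay for inhibition, with Homo sapiens as the target (a lower number here means a stronger inhibitor, a higher number a weaker inhibitor), compound 1 reaches only the limit > 48000 nM. Compound 2 likewise gives only the limit > 48000 nM in this assay. The change from compound 1 to compound 2 is methyl in place of hydrogen on a sulfur, and its step is a step that the two limits leave unreadable from compound 1 to compound 2, since both values sit at the limit of > 48000 nM in this assay, at which 3 of the 3 values shown sit. Compound 3 gives only the limit > 48000 nM in this assay. The change from compound 3 to compound 4 is methyl in place of hydrogen on a sulfur, the same change at the same place. Compound 4 is expected to sit near 48000 nM in this assay, between 20000 nM and 200000 nM. This rests on compound 3, whose value > 48000 nM is a limit, and on (the limit of > 48000 nM in this assay, at which 3 of the 3 values shown sit). The expected step from compound 3 to compound 4 is a number no higher from compound 3 to compound 4 (the limit leaves the size open).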

Compound 4, half-maximal inhibitory concentration: > 48000 nM
Compound 4: a limit, no number; the forecaster's own chance of this, stated with the estimate: 85%; the middle value sits exactly at the limit.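

Between compound 3 and compound 4 no step can be read in this assay because both values are limits: the limit of > 48000 nM in this assay, at which 4 of the 4 values shown sit.
The compounds shown leave open whether methyl in place of hydrogen on a sulfur changes inhibition on either core.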